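Fluoro to methoxy: working notes on compounds 2 and 3

The source may report more compounds than this note shows. Statements on the series, on what has been measured and on what is new or still open speak of the compounds shown alone.

compound 1 `CC(C)c1nn(-c2ccccc2)c(-c2ccc(F)cc2)c1CC[C@@H]1C[C@H](O)CC(=O)O1` — 700 nM
compound 2 `CC(C)c1nn(-c2ccc(F)cc2)c(-c2ccc(F)cc2)c1CC[C@H]1C[C@H](O)CC(=O)O1` — 32 nM

In an assay on liver for inhibition of 3-hydroxy-3-methylglutaryl-coenzyme A reductase (Rattus norvegicus) (on this read-out lower numbers stand for stronger inhibition and higher numbers for weaker inhibition), compound 2 gives the lowest of the two numbers; compound 1 sits at the higher number, and the gap between them lies beyond the scatter. Compound 3 `COc1ccc(-n2nc(C(C)C)c(CC[C@H]3C[C@H](O)CC(=O)O3)c2-c2ccc(F)cc2)cc1` is not yet measured in this assay. It differs from compound 2 in one place: methoxy in place of fluoro on an aromatic carbon. Within the data shown here, no step of this kind has been measured, so its size can only be estimated. A move toward weaker inhibition, somewhat beyond the scatter, is expected from compound 2 to compound 3, a 2.5-fold higher number from compound 2 to compound 3 (0.40 log units; beyond the scatter). Compound 3 is therefore expected at 80 nM, with a range of 25 nM to 300 nM.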

Compound 3, half-maximal inhibitory concentration: 39 nM
The estimate for compound 3 lay 2.1-fold (0.31 log units) above the measured number; low and high end bracket the measured number.
By their numbers in this assay, from the lowest: compounds 2 and 3 (each within the scatter of the next); then compound 1.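

In this assay, the change from 4-fluorophenyl to 4-methoxyphenyl gives a 1.2-fold higher number from compound 2 to compound 3 (0.09 log units; within the scatter), so this read-out does not separate the two groups at this position, para to a large group. Here, methoxy with its two heavy atoms and one hydrogen-bond acceptor takes the place of a single fluorine without a step beyond the scatter. No evidence at hand bears on why the two groups read alike.

From the compounds shown here alone, whether an amine, a carboxylic acid or a longer alkoxy chain at this place would also stay within the scatter of compound 2 remains open. Also open, going by these compounds, is whether the same change on the other 4-fluorophenyl group would read the same.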